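From Pentyl to Cyclopentyl on the Amide Nitrogen

A few compounds are considered here, and "the series" means these few. Any claim that something is new, unique, unknown or untested is made for them only; others in the source may bear on it.

Measured compounds:
compound 1, `COc1cc2c(cc1OC)C(CC(=O)N(C)C)CC2`: 36%
compound 2, `CCCCCNC(=O)CC1CCc2cc(OC)c(OC)cc21`: 34%

In a functional assay on the whole organism (strain Wistar) for inhibition, with Rattus norvegicus as the target, read by paw edema, with stated times of 60 min and 2 h, at a dose of 100 mg/kg by the oral route (a lower number here means less inhibition, a higher number more inhibition at the dose given (going by the name of the read-out)), compound 1 gives 36%, and compound 2 gives 34%. For the measured compounds named here, compound 2 thus holds the lower of the two numbers, but its only neighbour is compound 1, and the step of a number 2 percentage points lower from compound 1 to compound 2 (within the scatter) lies within the scatter, so the two cannot be told apart. Compound 3, `COc1cc2c(cc1OC)C(CC(=O)NC1CCCC1)CC2`, has not yet been measured in this assay. It differs from compound 2 in one place: cyclopentyl in place of pentyl on an amide-type nitrogen. Going by the values given here, the one measured step that bears on this position, the change from dimethylamino to pentylamino on the carbonyl carbon, gave a number 2 percentage points lower from compound 1 to compound 2 (within the scatter), so the amide substituent has so far left the read-out unchanged. On that basis the step of no change at the digits printed from compound 2 to compound 3 (within the scatter) is expected to stay within the scatter. Compound 3 is therefore estimated at 34%, with a range from 22% to 46%.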

Compound 3, a percentage reported as inhibition, in the whole organism at one dose (the size of the read-out at that dose, not a potency): 52%
For compound 3 the middle estimate is 18 percentage points below the measured one, and the stated range ends below it.
By their numbers in this assay, from the lowest: compounds 2 and 1 (each within the scatter of the next); then compound 3.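

In this assay, the amide nitrogen proves to be a position that can change the read-out: the step of a number 18 percentage points higher from compound 2 to compound 3 (beyond the scatter) exchanges pentyl for cyclopentyl with the same count of heavy atoms, so the two groups differ in the ring and not in their carbon count. The step of a number 16 percentage points higher from compound 1 to compound 3 (beyond the scatter) sets cyclopentylamino apart from dimethylamino as well, whereas pentylamino and dimethylamino could not be told apart, so not every change of this substituent moves the number. No available evidence accounts for this difference.

As far as these compounds go, whether a cyclobutyl or cyclohexyl group on the same nitrogen would read like cyclopentyl remains open. Also open, from the compounds shown here alone, is how a phenyl ring there would compare, or a methyl group added to that nitrogen alongside cyclopentyl.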